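Working notes: aryl substitution in a cytotoxic series

The compounds below may be only part of what the source reports. "The series", "measured", "known", "first", "only" and "open" are said of these compounds alone.

Values in a functional assay on cells (Cancer cell lines, Homo sapiens) for cytotoxicity, read by sulforhodamine B assay, with a stated time of 48 h; on this read-out higher numbers stand for weaker inhibition of growth and lower numbers for stronger inhibition of growth:
compound 1 `COc1ccc(C2CC(c3ccccc3)=NN2C2=NC(=O)/C(=C3\C(=O)Nc4ccccc43)S2)cc1`: 4390 nM
compound 2 `O=C1N=C(N2N=C(c3ccccc3)CC2c2ccc(Cl)cc2)S/C1=C1/C(=O)Nc2ccccc21`: 390 nM

Within the data shown here, the single measured step, an 11-fold lower number from compound 1 to compound 2 (1.05 log units; beyond the scatter), is large and leaves compound 2 with the lowest number of the two. Compound 3 `Cc1ccc2c(c1)/C(=C1\SC(N3N=C(c4ccccc4)CC3c3ccc(Cl)cc3)=NC1=O)C(=O)N2` differs from compound 2 by methyl in place of hydrogen on an aromatic carbon, on a six-membered aromatic ring of carbon only that is part of a fused system of two rings. Among the measured compounds shown here, no measured step touches this ring; the one step concerns a substituent on a different aromatic carbon, so it gives no guide to a methyl here. A step within the scatter is therefore expected in this assay. For compound 3 the expected value is 320 nM (range 110 nM to 1100 nM). This estimate means an expected 1.2-fold lower number from compound 2 to compound 3 (0.09 log units; within the scatter).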

Compound 3, concentration for total growth inhibition: 350 nM
For compound 3 the middle estimate is 1.1-fold (0.04 log units) below the measured one, and the stated range covers the measured number.
By their numbers in this assay, from the lowest: compounds 3 and 2 (each within the scatter of the next); then compound 1.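

In this assay the step on the six-membered aromatic ring of carbon only, part of the fused system, is a 1.1-fold lower number from compound 2 to compound 3 (0.05 log units; within the scatter) and stays within the scatter. This carbon, meta to a fused ring and para to a fused ring, therefore accepts methyl in place of hydrogen with the chloro compound held constant, whereas the earlier step concerned a different aromatic carbon. No supporting evidence bears on this result.

Open, going by these compounds, is whether an amine, a carboxylic acid or a longer chain on this carbon would also stay within the scatter. Also open, on these data alone, is whether methyl here behaves the same alongside methoxy in place of chloro.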